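This account rests on a few compounds, and the source may have more. Where it says the series, first, only, none or still open, it means among the compounds named here.

Compound 1 `Clc1ccc(-c2noc(Cn3ccnc3)n2)cc1` was tested in a toxicity assay on the whole organism (strain Wistar) with Rattus norvegicus as the target, with a stated time of 1 h; a lower number here means that less compound is needed, a higher number that more compound is needed for the effect. For compound 1 the read-out is a limit rather than a number, > 500 mg/kg, so it stands only at the limit of > 500 mg/kg in this assay, at which 1 of the 2 values shown sits. Compound 2 `c1ccc(-c2nc(Cn3cncn3)no2)cc1` is not a single-point neighbour of compound 1; in this assay compound 2 gives 335 mg/kg. The unmeasured compound 3 `Clc1ccc(-c2noc(Cn3cncn3)n2)cc1` differs from compound 1 by 1H-1,2,4-triazol-1-yl in place of 1H-imidazol-1-yl on a saturated chain carbon bound to an aromatic carbon. Going by the values given here, with no measured step of this kind, the step from compound 1 to compound 3 is expected to be an at least 1.1-fold lower number from compound 1 to compound 3 (0.04 log units; that floor lies within the scatter), nothing beyond the usual scatter. Compound 3 is thus estimated at 450 mg/kg, with a range from 250 mg/kg to 900 mg/kg.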

Compound 3, dose for half-maximal effect: < 100 mg/kg
Compound 3 was reported as a limit; the forecaster's own chance of this, stated with the estimate: 50%; at least 4.5-fold (0.65 log units) between middle value and limit.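

At this place, on a saturated chain carbon bound to an aromatic carbon, 1H-1,2,4-triazol-1-yl in place of 1H-imidazol-1-yl gives an at least 5.0-fold lower number from compound 1 to compound 3 (0.69 log units; beyond the scatter) in this assay. Going by these compounds alone, this is the first single-point pair, and it shows that this one ring exchange alone moves the read-out beyond the usual scatter. Compound 3 stands only as a limit: the limit of < 100 mg/kg in this assay, at which 1 of the 3 values shown sits.

From the compounds shown here alone, the exact size of the step stays open, as both of its ends are limits. Also open, going by these compounds, is how a 1H-tetrazol-1-yl group or an amine at this place would read.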